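Extending the chain on the indole-type nitrogen of compound 1

The source may hold more compounds than are shown below. What is called first, only, known or untested is meant among the compounds shown, and "the series" means these compounds.

Compound 1 `CCCn1ccc2cc(/C(C)=C/C(=O)Nc3ccccc3OCCCC(=O)O)ccc21` carries a propyl group on the aromatic nitrogen of its core. Among the measured compounds shown here, in an assay on Prostate gland for inhibition of steroid 5-alpha-reductase (Rattus norvegicus) (on this read-out lower numbers stand for stronger inhibition and higher numbers for weaker inhibition), compound 1 gives 190 nM, the highest of the three numbers measured so far. Its nearest neighbour is compound 3 `C/C(=C\C(=O)Nc1ccccc1OCCCC(=O)O)c1ccc2c(ccn2CC(C)C)c1`, which gives 160 nM, a gap that stays within the scatter (a 1.2-fold lower number from compound 1 to compound 3 (0.07 log units; within the scatter)). Further away is compound 2 `CCCCCn1ccc2cc(/C(C)=C/C(=O)Nc3ccccc3OCCCC(=O)O)ccc21`, which gives 23 nM; the step of an 8.3-fold lower number from compound 1 to compound 2 (0.92 log units; beyond the scatter) is beyond the scatter, while the step of a 7.0-fold higher number from compound 2 to compound 3 (0.84 log units; beyond the scatter) runs the other way.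

Compound 4 `CCCCC(C)n1ccc2cc(/C(C)=C/C(=O)Nc3ccccc3OCCCC(=O)O)ccc21` differs from compound 1 by 1-methylpentyl in place of propyl on an aromatic nitrogen. For the measured compounds named here, two measured steps bear on this change. The step from compound 1 to compound 2 lengthens the chain and brings a modest fall in the number, and the step from compound 2 to compound 3 shortens and branches it and brings a modest rise. Compound 4 combines a longer chain with a branch on the carbon bound to the aromatic nitrogen, so the two tendencies partly offset each other. He therefore expects a fall of moderate size, a 3.5-fold lower number from compound 1 to compound 4 (0.54 log units; beyond the scatter), and estimates compound 4 at 55 nM, within a range from 15 nM to 200 nM.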

Compound 4, half-maximal inhibitory concentration: 6 nM
The estimate for compound 4 lay 9.2-fold (0.96 log units) above the measured number; measured number below the stated range.
By their numbers in this assay, from the lowest: compound 4; then compound 2; then compounds 3 and 1 (each within the scatter of the next).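

On the aromatic nitrogen of the shared core, 1-methylpentyl gives the lowest number yet in this assay, and the two steps to it from the shorter chains are large: a 32-fold lower number from compound 1 to compound 4 (1.50 log units; beyond the scatter) and a 27-fold lower number from compound 3 to compound 4 (1.43 log units; beyond the scatter). The earlier compounds shown here showed a branched chain giving a higher number than the butyl-extended compound 2, yet a branch on the carbon bound to the aromatic nitrogen of the long chain gives a further gain, a 3.8-fold lower number from compound 2 to compound 4 (0.58 log units; beyond the scatter). A methyl added to the chain, on a different chain carbon in each case, therefore does not count the same on the shorter and the longer chain: the same change on two cores in this assay, a 1.2-fold lower number (0.07 log units; within the scatter) from compound 1 to compound 3 and a 3.8-fold lower number (0.58 log units; beyond the scatter) from compound 2 to compound 4, 3.2-fold (0.51 log units) apart, beyond the scatter of two such steps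

As far as these compounds go, whether the number keeps falling with a longer branched chain such as 1-methylhexyl, or with a second methyl on the carbon bound to the aromatic nitrogen, remains open. From the compounds shown here alone, it is also open how a ring such as cyclohexyl on that nitrogen, or a hydroxyl group at the end of the chain, would compare with 1-methylpentyl.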